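The source may hold more compounds than are shown below. What is called first, only, known or untested is meant among the compounds shown, and "the series" means these compounds.

Measured so far:

Compound 1, `OC(c1ccc(Cl)cc1)(c1ccc(Br)cc1)c1cccnc1`, gives 57000 nM in an ADME assay on L6 cells (Rattus norvegicus) for cytotoxicity, read by resazurin assay, with a stated time of 72 h; a higher number here means a weaker inhibitor, a lower number a stronger inhibitor.
Compound 2, `OC(c1ccc(Cl)cc1)(c1ccc(C(F)(F)F)cc1)c1cccnc1`, gives 56400 nM in this assay.
Compound 3, `OC(c1ccc(Cl)cc1)(c1cccnc1)c1ccc(C(F)(F)F)cc1F`, gives 57400 nM in this assay.

Compound 4, `OC(c1ccc(Cl)cc1)(c1cccnc1)c1ccc(Br)cc1F`, has not yet been measured. Its relation to compound 3 is bromo in place of trifluoromethyl on an aromatic carbon. The same kind of change appears between two measured compounds, (bromo in place of trifluoromethyl on an aromatic carbon), where the step was a 1.0-fold higher number from compound 2 to compound 1 (0.00 log units; within the scatter). The cores of compound 2 and compound 3 differ by fluoro in place of hydrogen on an aromatic carbon, so in compound 4 the bromo group sits meta to a fluoro group as well as para to a large group, which the earlier pair lacked. All three measured values sit within the scatter of one another. Resting on the earlier step, compound 4 is expected to show a 1.0-fold lower number from compound 3 to compound 4 (0.00 log units; within the scatter). The estimated value for compound 4 is 57000 nM, between 30000 nM and 110000 nM.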

Compound 4, half-maximal inhibitory concentration: 79200 nM
Beside the measured number, compound 4's estimate is 1.4-fold (0.14 log units) below it; low and high end bracket the measured number.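

In this assay, bromo in place of trifluoromethyl gives a 1.4-fold higher number from compound 3 to compound 4 (0.14 log units; within the scatter) and agrees with the same change on the core lacking the fluoro group: the same change on two cores in this assay, a 1.0-fold higher number (0.00 log units; within the scatter) from compound 2 to compound 1 and a 1.4-fold higher number (0.14 log units; within the scatter) from compound 3 to compound 4, 1.4-fold (0.14 log units) apart, within the scatter of two such steps. Fluoro in place of hydrogen gives a 1.4-fold higher number from compound 1 to compound 4 (0.14 log units; within the scatter) and likewise agrees with its earlier step: the same change on two cores in this assay, a 1.0-fold higher number (0.01 log units; within the scatter) from compound 2 to compound 3 and a 1.4-fold higher number (0.14 log units; within the scatter) from compound 1 to compound 4, 1.4-fold (0.14 log units) apart, within the scatter of two such steps. Within the data shown here, both changes therefore carried between these two cores without a detectable difference, but with every step within the scatter, this shows only that neither change measurably moved the number, not that an effect of any particular size transfers.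

The compounds shown leave open whether this holds for other groups at the same place, such as an amine, a carboxylic acid or a nitrile. They also leave open whether replacing the chloro group would carry over in the same way.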